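The source may hold more compounds than are shown below. What is called first, only, known or untested is meant among the compounds shown, and "the series" means these compounds.

Measured so far in a functional assay on HCT-116 cells (Homo sapiens) for antiproliferative activity, read by MTT assay, with a stated time of 24 h; a lower number here means a stronger inhibitor, a higher number a weaker inhibitor:
- Compound 1 `COc1ccc(C(=O)/C=C/c2ccc(Br)cc2)c2c1C=CC(C)(C)O2`: > 10000 nM (a limit)
- Compound 2 `COc1ccc(C(=O)/C=C/c2ccc([N+](=O)[O-])cc2)c2c1C=CC(C)(C)O2`: 8880 nM
- Compound 3 `COc1ccc(/C=C/C(=O)c2ccc(OC)c3c2OC(C)(C)C=C3)cn1`: > 10000 nM (a limit)

Compound 3 stands at a limit, > 10000 nM, not at a true number. It has company there: the limit of > 10000 nM in this assay, at which 2 of the 3 values shown sit.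

Compound 4 `COc1ccc(C(=O)/C=C/c2ccc(Cl)cc2)c2c1C=CC(C)(C)O2` carries 4-chlorophenyl in place of 6-methoxypyridin-3-yl on a double-bonded chain carbon bound to a double-bonded chain carbon.

Three measured steps swap this same aryl group or a substituent on it. Two give only floors: an at least 1.1-fold lower number from compound 1 to compound 2 (0.05 log units; that floor lies within the scatter) and an at least 1.1-fold higher number from compound 2 to compound 3 (0.05 log units; that floor lies within the scatter). The third cannot be sized: a step that the two limits leave unreadable from compound 1 to compound 3.

No step beyond the scatter is therefore expected, and the estimate is a step that the limit leaves unreadable from compound 3 to compound 4. Compound 4 is expected near 12000 nM, with an estimated range of 5000 nM to 30000 nM.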

Compound 4, half-maximal inhibitory concentration: > 10000 nM
Compound 4: only a limit was reported; the forecaster's own chance of this, stated with the estimate: 65%; the middle value is on the limit's open side.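

In this assay compound 4 gives > 10000 nM, which is a limit and not a true number. Chloro in place of nitro on an aromatic carbon gives an at least 1.1-fold higher number from compound 2 to compound 4 (0.05 log units; that floor lies within the scatter), while the steps to compound 4 from compound 1 and from compound 3 cannot be read. With chloro, bromo and 6-methoxypyridin-3-yl versions all unresolved, compound 4 joins compound 1 and compound 3 at one shared limit: the limit of > 10000 nM in this assay, at which 3 of the 4 values shown sit.

So chloro and bromo cannot be ranked against each other. On these data alone, whether an amine or a carboxylic acid on an aromatic carbon here would give a true number well short of this limit stays open.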